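This account rests on a few compounds, and the source may have more. Where it says the series, first, only, none or still open, it means among the compounds named here.

Compound 1 `CC(C)(C)c1ccc(-c2ccc3c(C(=O)Nc4cccc(F)c4)cc(=O)[nH]c3c2)cc1`: > 20000 nM
Compound 2 `O=C(Nc1cccc(F)c1)c1cc(=O)[nH]c2cc(-c3ccsc3)ccc12`: 4300 nM

The entry for compound 1 is a limit, not a number. Within the data shown here, compound 2 therefore holds the only number so far in a functional assay on KYSE-410 cells (Homo sapiens) for antiproliferative activity, read by MTT assay, with a stated time of 72 h (a higher number here means a weaker inhibitor, a lower number a stronger inhibitor), 4300 nM. Compound 3 `Cc1ccc(-c2ccc3c(C(=O)Nc4cccc(F)c4)cc(=O)[nH]c3c2)cc1` carries 4-methylphenyl in place of thiophen-3-yl on an aromatic carbon. Among the measured compounds shown here, one measured step bears on this change: an at least 4.6-fold lower number from compound 1 to compound 2 (0.66 log units; beyond the scatter), which lies beyond the scatter and replaced 4-(tert-butyl)phenyl with thiophen-3-yl. Returning to a substituted phenyl should partly reverse that step, so a modest rise in the number is expected. The expected change is a 2.1-fold higher number from compound 2 to compound 3 (0.32 log units; beyond the scatter). The estimate for compound 3 is 9000 nM, with an expected range of 3500 nM to 20000 nM.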

Compound 3, half-maximal inhibitory concentration: > 20000 nM
Compound 3 ended at the assay's limit (the forecaster's own chance of this, stated with the estimate: 25%); middle value at least 2.2-fold (0.34 log units) from the limit.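

In this assay, the change gave an at least 4.6-fold higher number from compound 2 to compound 3 (0.66 log units; beyond the scatter), so the loss on leaving thiophen-3-yl is not confined to 4-(tert-butyl)phenyl: it also appears with 4-methylphenyl at this position, para to a fused ring. Of the three groups shown on this aromatic carbon, only thiophen-3-yl gives a number. The step from compound 1 to compound 3 cannot be read, since both entries are limits: the limit of > 20000 nM in this assay, at which 2 of the 3 values shown sit.

As far as these compounds go, whether compound 1 and compound 3 truly differ stays open. So does how an unsubstituted phenyl, a furan-3-yl or a pyridin-3-yl would read at this position.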